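Moving the Methoxy Group Around the Benzyl Ring

This account rests on a few compounds, and the source may have more. Where it says the series, first, only, none or still open, it means among the compounds named here.

Compound 1 `COc1ccc(CNC(=O)c2nc(-c3ccc(F)cc3)n(CC[C@@H](O)C[C@@H](O)CC(=O)O)c2C2CC2)cc1` has been measured in an assay on microsomes from liver for inhibition of 3-hydroxy-3-methylglutaryl-coenzyme A reductase (Rattus norvegicus), read by scintillation counting, with stated times of 0.5 h and 0.75 h (a higher number here means a weaker inhibitor, a lower number a stronger inhibitor), where compound 1 gives 1.2 nM. Among the measured compounds shown here, its only measured neighbour is compound 2 `COc1cccc(CNC(=O)c2nc(-c3ccc(F)cc3)n(CC[C@@H](O)C[C@@H](O)CC(=O)O)c2C2CC2)c1`, which in this assay gives 1.2 nM; the step is no change at the digits printed from compound 1 to compound 2 (within the scatter), so compound 1 stands level with compound 2 on the single comparison available. The unmeasured compound 3 `COc1ccccc1CNC(=O)c1nc(-c2ccc(F)cc2)n(CC[C@@H](O)C[C@@H](O)CC(=O)O)c1C1CC1` differs from compound 1 by 2-methoxyphenyl in place of 4-methoxyphenyl on a saturated chain carbon bound to an amide-type nitrogen. For the measured compounds named here, the one measured step that bears on this change is no change at the digits printed from compound 1 to compound 2 (within the scatter), where the methoxy group moved from 4-methoxyphenyl to 3-methoxyphenyl with no shift beyond the scatter. Going by the values given here, no measured step reaches 2-methoxyphenyl, so that move is untested, and the expected step is kept small but given a wide range: a 1.7-fold higher number from compound 1 to compound 3 (0.22 log units; within the scatter). Compound 3 is therefore estimated at 2 nM in this assay, between 0.6 nM and 8 nM.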

Compound 3, half-maximal inhibitory concentration in the 3-hydroxy-3-methylglutaryl-coenzyme A reductase assay: 7 nM
Beside the measured number, compound 3's estimate is 3.5-fold (0.54 log units) below it; low and high end bracket the measured number.
By their numbers in the 3-hydroxy-3-methylglutaryl-coenzyme A reductase assay, from the lowest: compounds 1 and 2 (each within the scatter of the next); then compound 3.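

Among the compounds shown here, the 2-methoxyphenyl group is the first change at this position to register in the 3-hydroxy-3-methylglutaryl-coenzyme A reductase assay, with a 5.8-fold higher number from compound 1 to compound 3 (0.77 log units; beyond the scatter) and a 5.8-fold higher number from compound 2 to compound 3 (0.77 log units; beyond the scatter), so the place of the methoxy group on the benzyl ring does matter, even though 4-methoxyphenyl and 3-methoxyphenyl could not be told apart. In a physicochemical assay for lipophilicity, using the shake flask method, at pH 7.4 (on this read-out lower numbers stand for lower lipophilicity and higher numbers for higher lipophilicity), compound 1 gives 0.02 and compound 3 gives 0.16, two values within the scatter of each other, so the drop in inhibition comes without a measurable shift on that read-out. Nothing available explains the weaker inhibition by compound 3.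

From the compounds shown here alone, it stays open whether the step belongs to the methoxy group itself or to any group placed there. Unsubstituted phenyl, 2-chlorophenyl or 2-hydroxyphenyl in the same place would be needed to tell these apart.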